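This account rests on a few compounds, and the source may have more. Where it says the series, first, only, none or still open, it means among the compounds named here.

Series notes. The measured compounds are compound 1 `COc1cc2c(Nc3nc4ccc(C(=O)Nc5c(C)cccc5Cl)cc4s3)ncnc2cc1OCCCN1CCCCC1C`, compound 2 `COc1cc2c(Nc3nc4ccc(C(=O)Nc5c(C)cccc5C)cc4s3)ncnc2cc1OCCCN1CCCC1` and compound 3 `COc1cc2c(Nc3nc4ccc(C(=O)Nc5c(C)cc(C)cc5C)cc4s3)ncnc2cc1OCCCN1CCCCC1C`. In a functional assay on K562 cells (Homo sapiens) for cytotoxicity, read by WST assay, with a stated time of 72 h (on this read-out higher numbers stand for weaker inhibition and lower numbers for stronger inhibition), compound 2 gives 15700 nM, the highest of the three numbers; compound 1 gives 6800 nM and compound 3 gives 3500 nM, and both gaps to compound 2 are beyond the scatter. Among the measured compounds shown here, the only single-point step among the measured compounds is a 1.9-fold lower number from compound 1 to compound 3 (0.29 log units; within the scatter), and it concerns the aryl amide rather than the group on the saturated chain carbon.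

Compound 4 `COc1cc2c(Nc3nc4ccc(C(=O)Nc5c(C)cccc5C)cc4s3)ncnc2cc1OCCCN1CCC(C)CC1` keeps the rest of compound 2 and differs in one place: 4-methylpiperidin-1-yl in place of pyrrolidin-1-yl on a saturated chain carbon, three bonds along the chain from an oxygen on an aromatic ring. For the measured compounds named here, no measured step bears on this change alone. Compound 1 and compound 3 both carry 2-methylpiperidin-1-yl at that place and sit lower than compound 2, but each also differs from compound 2 in the aryl amide, so their values cannot be split between the two changes. Without a direct precedent, the step expected here, a 1.7-fold lower number from compound 2 to compound 4 (0.24 log units; within the scatter), is modest, towards a lower number, and not clearly beyond the scatter. Compound 4 is therefore estimated at 9000 nM in this assay, with a range from 3500 nM to 22000 nM.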

Compound 4, half-maximal inhibitory concentration: 15800 nM
The estimate for compound 4 lay 1.8-fold (0.24 log units) below the measured number; measured number inside the range.
By their numbers in this assay, from the lowest: compounds 3 and 1 (each within the scatter of the next); then compounds 2 and 4 (each within the scatter of the next).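

In this assay, among the compounds shown here, replacing pyrrolidin-1-yl with 4-methylpiperidin-1-yl on a saturated chain carbon, three bonds along the chain from an oxygen on an aromatic ring, gives a 1.0-fold higher number from compound 2 to compound 4 (0.00 log units; within the scatter), the first direct reading of a change at this place. With the aryl amide and the rest of compound 2 held fixed, this assay does not separate the five-membered ring from the six-membered ring bearing a methyl group, so this pair gives no sign that this exchange alone moves the number. No other measurement bears on this result, and the similarity of the two values remains unexplained.

Still open, as far as these compounds go, is whether 2-methylpiperidin-1-yl would read differently from 4-methylpiperidin-1-yl or pyrrolidin-1-yl on the aryl amide of compound 2, and whether the same exchange would read alike on the 2-chloro-6-methylphenyl or 2,4,6-trimethylphenyl amide. The compounds shown also leave open how a morpholin-4-yl group, a dimethylamino group or a longer chain would read at this place.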